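This account rests on a few compounds, and the source may have more. Where it says the series, first, only, none or still open, it means among the compounds named here.

Compound 2 `COc1cc(OC)cc(C(=O)NC2CCN(Cc3ccc4ccccc4c3)CC2)c1` gives the lowest number of the three measured in an assay on isolated protein for binding affinity to melanin-concentrating hormone receptor 1 (Homo sapiens) (a higher number here means a weaker inhibitor, a lower number a stronger inhibitor), at 27 nM. Compound 1 `O=C(NC1CCN(Cc2ccc3ccccc3c2)CC1)c1ccccc1` gives 347 nM, and compound 3 `COc1cc(C(=O)NC2CCN(Cc3ccc4ccccc4c3)CC2)cc(OC)c1OC` gives 286 nM. Both measured steps alter the benzoyl side of the shared core: a 13-fold lower number from compound 1 to compound 2 (1.11 log units; beyond the scatter), and an 11-fold higher number from compound 2 to compound 3 (1.03 log units; beyond the scatter). Compound 4 `COc1cc(OC)cc(C(=O)NC2CCN(C(C)c3ccc4ccccc4c3)CC2)c1` differs from compound 2 elsewhere, at (methyl in place of hydrogen on a saturated chain carbon bound to an amine nitrogen in a ring and an aromatic carbon), so the change sits on the chain joining the ring amine to the aromatic system, a place not probed by either measured step. Neither step therefore bears directly on it, and there is no basis in these data for a large shift in this assay in either direction; a step within the scatter, or a small one, is what the account expects. On this basis compound 4 is estimated at 40 nM, with a range from 12 nM to 130 nM, the expected step being a 1.5-fold higher number from compound 2 to compound 4 (0.17 log units; within the scatter).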

Compound 4, inhibition constant: 25 nM
Estimate against measurement, compound 4: 1.6-fold (0.20 log units) above; the range from low to high includes it.
By their numbers in this assay, from the lowest: compounds 4 and 2 (each within the scatter of the next); then compounds 3 and 1 (each within the scatter of the next).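

Among these compounds, the chain carbon bound to an amine nitrogen in a ring and an aromatic carbon is a place the earlier compounds left untouched, and in this assay methyl in place of hydrogen there gives a 1.1-fold lower number from compound 2 to compound 4 (0.03 log units; within the scatter). Adding this one heavy atom thus leaves the number within the scatter, unlike the two large steps on the benzoyl side of the shared core, a 13-fold lower number from compound 1 to compound 2 (1.11 log units; beyond the scatter) and an 11-fold higher number from compound 2 to compound 3 (1.03 log units; beyond the scatter). Nothing measured here accounts for this result.

The compounds shown leave open whether a larger group at this carbon, such as ethyl or phenyl, or a different one, such as hydroxyl or a carboxylic acid, would also leave the number within the scatter. They also leave open whether the same methyl would give a similar step with the unsubstituted phenyl of compound 1 or the trimethoxyphenyl of compound 3.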